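Nitro replaced by fluoro: one change, one earlier example

The source may report more compounds than this note shows. Statements on the series, on what has been measured and on what is new or still open speak of the compounds shown alone.

Measured in a toxicity assay on the whole organism with Rattus norvegicus as the target, at a dose of 400 mg/kg by the oral route; a higher number here means a stronger effect of the compound at the dose given, a lower number a weaker effect:
Compound 1, `Fc1ccc(OCC2=NCCO2)cc1`, gave 50%.
Compound 2, `O=[N+]([O-])c1ccccc1OCC1=NCCO1`, gave 90%.
Compound 3, `O=[N+]([O-])c1ccc(OCC2=NCCO2)cc1`, gave 100%.

Compound 3 and compound 1 differ in a single place: fluoro in place of nitro on an aromatic carbon. In this assay that change made the step of a number 50 percentage points lower from compound 3 to compound 1 (beyond the scatter). Compound 2 and compound 3 are built from the same atoms joined differently; the difference between the two cores is not broken down here. Their values in this assay lie within the usual scatter of each other.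

Compound 4, `Fc1ccccc1OCC1=NCCO1`, has not yet been measured. It differs from compound 2 by fluoro in place of nitro on an aromatic carbon. The surroundings are not identical to the earlier case: in compound 1 the fluoro stands para to a group of 7 heavy atoms, in compound 4 ortho to a group of 7 heavy atoms, so this is the same kind of change rather than the same change.

From compound 2 to compound 4 in this assay a step of about a number 45 percentage points lower from compound 2 to compound 4 (beyond the scatter) is expected, beside the earlier a number 50 percentage points lower from compound 3 to compound 1 (beyond the scatter), because compound 2 starts from 90%. Going by the values given here, the single earlier example leaves the width uncertain. Compound 4 is estimated at 45%, expected between 20% and 75%.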

Compound 4, a percentage reported as activity, at one dose (the size of the read-out at that dose, not a potency): 80%
Compound 4: the middle estimate sits 35 percentage points below what was measured; the whole stated range lies below it.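

In this assay, fluoro in place of nitro on an aromatic carbon gave a number 10 percentage points lower from compound 2 to compound 4 (within the scatter) and so no readable change on this core. Set beside the earlier example, the same change does not carry over as one fixed step from one core to the other: the same change on two cores in this assay, a number 50 percentage points lower (beyond the scatter) from compound 3 to compound 1 and a number 10 percentage points lower (within the scatter) from compound 2 to compound 4, 40 percentage points apart, beyond the scatter of two such steps. Going by these compounds alone, with only two examples, this does not show why the two steps differ, nor what the change would do on any further core.

The compounds shown carry only nitro or fluoro on the aromatic ring, so it remains open how this assay would read with a different group on that ring, such as an amine or a carboxylic acid. As far as these compounds go, it also remains open whether a longer chain linking the aromatic ring to the rest of the molecule would alter the picture.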